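The source may hold more compounds than are shown below. What is called first, only, known or untested is meant among the compounds shown, and "the series" means these compounds.

Measured in an assay on isolated protein for inhibition of Rho-associated protein kinase 1 (Homo sapiens), read by scintillation counting, radiometric assay and 33P incorporation, with a stated time of 40 min, in the presence of a further agent that is not named here; on this read-out higher numbers stand for weaker inhibition and lower numbers for stronger inhibition:

compound 1 `Cc1ccc(NC(=O)COc2ccc3c(=O)ccoc3c2)cc1NC(=O)c1ccc(N(C)C)cc1`, 1040 nM
compound 2 `Cc1cc(NC(=O)COc2ccc3c(=O)ccoc3c2)cc(NC(=O)c2ccc(N(C)C)cc2)c1C`, 3950 nM
compound 3 `CN(C)c1ccc(C(=O)Nc2ccc(NC(=O)COc3ccc4c(=O)ccoc4c3)cc2)cc1`, 1050 nM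

Among the measured compounds shown here, the one counted step in the set is methyl in place of hydrogen on an aromatic carbon, which gave a 3.8-fold higher number from compound 1 to compound 2 (0.58 log units; beyond the scatter). The difference between the core of compound 1 and the core of compound 3 is not broken down here; in this assay the two give numbers that lie within the scatter of each other.

Compound 4 `Cc1cc(NC(=O)COc2ccc3c(=O)ccoc3c2)ccc1NC(=O)c1ccc(N(C)C)cc1` is not yet measured. It differs from compound 3 by methyl in place of hydrogen on an aromatic carbon. This is the same kind of change as that from compound 1 to compound 2, but not the same: there the entering methyl sat ortho to a methyl group and meta to a ((4-(dimethylamino)phenyl)carbonyl)amino group, here it sits ortho to a large group. The expectation for this assay rests on compound 2, whose step a 3.8-fold higher number from compound 1 to compound 2 (0.58 log units; beyond the scatter) went to a higher number; a somewhat smaller step, a 2.5-fold higher number from compound 3 to compound 4 (0.39 log units; beyond the scatter), is estimated. Compound 4 is therefore expected to give about 2600 nM, within 1200 nM to 6000 nM.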

Compound 4, half-maximal inhibitory concentration: > 10000 nM
Compound 4: no number, only a limit; the forecaster's own chance of this, stated with the estimate: 2%; middle value at least 3.8-fold (0.58 log units) away from the limit.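

Methyl in place of hydrogen on an aromatic carbon gave an at least 9.5-fold higher number from compound 3 to compound 4 (0.97 log units; beyond the scatter), so in this assay the change goes to a higher number on both cores: the same change on two cores in this assay, a 3.8-fold higher number (0.58 log units; beyond the scatter) from compound 1 to compound 2 and an at least 9.5-fold higher number (0.97 log units; beyond the scatter) from compound 3 to compound 4; the limit leaves it open whether they differ

Compound 4 reads > 10000 nM, which is a limit of the assay and not a number. The two cores therefore show that the direction carries over, but not whether the size does, and two cases make no general rule for the series.

Still open, on these data alone, is whether fluorine or methoxy in place of the methyl would also raise the number. As far as these compounds go, it is also open whether the step holds when a carboxylic acid or a cyclic amine replaces the dimethylamino group.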